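Removing a Methoxy Group: Effect on Metabolic Stability

A few compounds are considered here, and "the series" means these few. Any claim that something is new, unique, unknown or untested is made for them only; others in the source may bear on it.

Two compounds sharing a nitrofuran amide attached to a fused two-ring core have been measured in an ADME assay on microsomes from liver (Homo sapiens) for metabolic stability; a higher number here means faster removal of the compound, a lower number slower removal. Compound 1 `O=C(Nc1ccc(-c2cnc3ccccn23)cc1)c1ccc([N+](=O)[O-])o1` carries no substituent on the core; in this assay compound 1 gives 85.1 mL.min-1.g-1. Compound 2 `COc1ccn2c(-c3ccc(NC(=O)c4ccc([N+](=O)[O-])o4)c(C)c3)cnc2c1` adds a methoxy group to the core and a methyl group on the central benzene ring; in this assay compound 2 gives 52.6 mL.min-1.g-1. Of the two numbers, that of compound 2 is the lower, but the gap to compound 1 lies within the scatter of repeated measurements, so the two compounds cannot be told apart on this evidence.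

Compound 3 `Cc1cc(-c2cnc3ccccn23)ccc1NC(=O)c1ccc([N+](=O)[O-])o1` differs from compound 2 in one place: hydrogen in place of methoxy on an aromatic carbon. Within the data shown here, no pair of measured compounds shows the effect of this particular change, so there is no direct guide. Since both measured compounds, with and without the methoxy group on the core, sit within the scatter of each other, the expectation is a step from compound 2 to compound 3 of a 1.2-fold higher number from compound 2 to compound 3 (0.09 log units; within the scatter), with no change beyond the scatter. Compound 3 is therefore estimated at 65 mL.min-1.g-1, with a range from 30 mL.min-1.g-1 to 130 mL.min-1.g-1.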

Compound 3, intrinsic clearance in microsomes: 57.2 mL.min-1.g-1
Estimate against measurement, compound 3: 1.1-fold (0.06 log units) above; the measured number falls inside the stated range.
By their numbers in this assay, from the lowest: compounds 2, 3 and 1 (each within the scatter of the next).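

In this assay, among these compounds, the step of a 1.1-fold higher number from compound 2 to compound 3 (0.04 log units; within the scatter) gives the first direct reading of hydrogen in place of methoxy on this aromatic carbon, opposite the ring nitrogen, and it shows that this change alone does not move the number beyond the scatter. Compound 3 also connects to compound 1 through a single change, methyl in place of hydrogen on an aromatic carbon, and the step of a 1.5-fold lower number from compound 1 to compound 3 (0.17 log units; within the scatter) likewise stays within the scatter, so the two differences between compounds 1 and 2 can now be read separately, and neither step is large enough to be told apart from repeated measurement. No measurement shown gives a reason for either result.

On these data alone, it remains open whether a different group at this position, such as an amine, a carboxylic acid or a longer chain like ethoxy, would produce a step beyond the scatter. All three compounds also keep the nitro group on the furan, so the compounds shown say nothing about how replacing it with another group, such as a nitrile, would affect removal in this assay.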